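Oxazole ketone series: fluoro replacing the pyrimidinyl ring

A few compounds are considered here, and "the series" means these few. Any claim that something is new, unique, unknown or untested is made for them only; others in the source may bear on it.

Among the compounds with values here, compound 2 `O=C(CCCCCCc1ccccc1)c1ncc(-c2ncccn2)o1` is the stronger of the two numbers so far in an assay (Rattus norvegicus) for inhibition of Fatty-acid amide hydrolase 1 (Homo sapiens) (a lower number here means a stronger inhibitor, a higher number a weaker inhibitor), where compound 2 gives 5.3 nM. Its nearest neighbour is compound 1 `NC(=O)c1cccc(-c2cnc(C(=O)CCCCCCc3ccccc3)o2)c1`, which in this assay gives 6 nM; the step of a 1.1-fold lower number from compound 1 to compound 2 (0.05 log units; within the scatter) is within the scatter, so the two are indistinguishable.

Compound 3 `O=C(CCCCCCc1ccccc1)c1ncc(F)o1` is the next member to be measured. The change from compound 2 is fluoro in place of pyrimidin-2-yl on an aromatic carbon.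

Within the data shown here, only one measured step exists, and it swaps one six-membered aromatic ring for another at the same carbon; it says nothing about removing the ring altogether and putting a single heavy atom there. The size of a 1.1-fold lower number from compound 1 to compound 2 (0.05 log units; within the scatter) therefore gives no direct guide. Among the measured compounds shown here, with no measured step that removes a ring from this position, the expected step of an 11-fold higher number from compound 2 to compound 3 (1.05 log units; beyond the scatter) for compound 3 is set toward a weaker inhibitor, but the width of the range is broad.

Compound 3 is expected to give about 60 nM in this assay, within a range of 12 nM to 300 nM.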

Compound 3, inhibition constant: 30 nM
The estimate for compound 3 lay 2.0-fold (0.30 log units) above the measured number, within the range that was stated.
By their numbers in this assay, from the lowest: compounds 2 and 1 (each within the scatter of the next); then compound 3.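

Within the data shown here, this is the first step at this position that takes the aromatic ring away rather than swapping it for another, and it has a cost: in this assay, there is a 5.7-fold higher number from compound 2 to compound 3 (0.75 log units; beyond the scatter), and likewise a 5.0-fold higher number from compound 1 to compound 3 (0.70 log units; beyond the scatter), each beyond the scatter but modest. An aromatic ring on the carbon next to the ring oxygen therefore contributes to the strength of inhibition in this short set, yet a single fluoro there, with no ring, still leaves compound 3 an inhibitor with a measurable number. No supporting evidence bears on why the number rises when the ring leaves.

With fluoro as the only non-ring group at this carbon, the compounds shown cannot separate the effect of losing the ring from any effect specific to fluoro; hydrogen, chloro, methyl or a nitrile at the same place would address that. Also open, from the compounds shown here alone, is whether a ring is needed at full size, which a smaller five-membered ring such as a thiazole or furan, or a carboxylic acid on the phenyl ring, would begin to test.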